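The source may hold more compounds than are shown below. What is called first, only, known or untested is meant among the compounds shown, and "the series" means these compounds.

Compounds measured so far: compound 1 `Cn1c(-c2ccc(NC(=O)CSc3nc4ccccc4s3)cc2)nc(-c2ccccc2)c1-c1ccccc1` with 15.3% and compound 2 `Cn1cnnc1SCC(=O)Nc1ccc(-c2nc(-c3ccccc3)c(-c3ccccc3)n2C)cc1` with 40.8% in a functional assay on HT-29 cells (Homo sapiens) for cytotoxicity, read by MTT assay, with a stated time of 24 h, tested at 1.6 ug/mL; a lower number here means a weaker effect, a higher number a stronger effect of the compound at the concentration tested.

Compound 2 stands highest of the two numbers; the nearest is compound 1, and the step of a number 25.5 percentage points higher from compound 1 to compound 2 (beyond the scatter) lies beyond the scatter.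

Compound 3 `CCN1CCN(CC(=O)Nc2ccc(-c3nc(-c4ccccc4)c(-c4ccccc4)n3C)cc2)CC1` follows from compound 2 by the change (4-ethylpiperazin-1-yl in place of (4-methyl-4H-1,2,4-triazol-3-yl)sulfanyl on a saturated chain carbon bound to a carbonyl carbon). Going by the values given here, the only measured step at this part of the chain is a number 25.5 percentage points higher from compound 1 to compound 2 (beyond the scatter), which shows that the group on this carbon shifts the read-out by a modest amount. Among the compounds with values here, no step removes the sulfur itself, so the direction is open; a modest move, here guessed downward, is expected: a number 10.8 percentage points lower from compound 2 to compound 3 (beyond the scatter). Compound 3 is estimated at 30%, within 10% to 55%.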

Compound 3, a percentage reported as activity, at one concentration (the size of the read-out at that concentration, not a potency): 13.9%
Beside the measured number, compound 3's estimate is 16.1 percentage points above it, and the stated range covers the measured number.
By their numbers in this assay, from the lowest: compounds 3 and 1 (each within the scatter of the next); then compound 2.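

In this assay, the (4-methyl-4H-1,2,4-triazol-3-yl)sulfanyl group stands apart among the groups on this saturated chain carbon bound to a carbonyl carbon: a number 26.9 percentage points lower from compound 2 to compound 3 (beyond the scatter), whereas a number 1.4 percentage points lower from compound 1 to compound 3 (within the scatter). Sulfur alone therefore does not set the read-out, as compound 1 keeps a sulfur and compound 3 has none, yet their numbers lie within the scatter of each other. Nothing available explains the difference. Still open, from the compounds shown here alone, is what a dimethylamino group, a morpholin-4-yl group or a sulfanyl-linked carboxylic acid on this carbon would give.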